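The source may report more compounds than this note shows. Statements on the series, on what has been measured and on what is new or still open speak of the compounds shown alone.

In a physicochemical assay for metabolic stability, read by HPLC, in phosphate buffer, with a stated time of 12 h, at pH 7.2 (on this read-out lower numbers stand for a shorter-lived compound and higher numbers for a longer-lived compound), compound 2 `O=C(N[C@H](CO)C(=O)O)[C@@H]1C[C@@H](O)CN1` gives > 12 h as its half-life, which is a limit and not a number. Compound 1 `O=C(O)[C@H](CO)NC(=O)[C@@H]1C[C@H](O)CN1` gives > 12 h here, again a limit. Two facts frame the comparison, namely the limit of > 12 h in this assay, at which 2 of the 2 values shown sit, and the fact that compounds 1 and 2 differ only in the configuration as drawn together. Compound 3 `O=C(O)[C@H](CO)NC(=O)[C@@H]1C[C@@H](O)CN1` departs from compound 2 by the two compounds have the same atoms and bonds and differ only in configuration as drawn: 1 of 3 stereo elements differ; a stereocentre at a saturated chain carbon is drawn R in compound 2 and S in compound 3 and nothing else. No step beyond the usual scatter is expected in this assay in either direction because a step that the two limits leave unreadable from compound 1 to compound 2 offers no size to carry over. The expected change is a step that the limit leaves unreadable from compound 2 to compound 3 in this estimate. Compound 3 is estimated at 16 h with an expected range from 10 h to 30 h overall.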

Compound 3, half-life: > 12 h
Compound 3 gave a limit, no number (the forecaster's own chance of this, stated with the estimate: 90%); the middle value does not contradict the limit.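

No step can be read among compound 1, compound 2 and compound 3, and one fact stands in the way: the limit of > 12 h in this assay, at which 3 of the 3 values shown sit.

The compounds shown leave open how long each one actually lasts, and whether changing the configuration as drawn alters its half-life at all.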